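The source may hold more compounds than are shown below. What is called first, only, known or untested is meant among the compounds shown, and "the series" means these compounds.

Of the compounds shown here, three that share one core have been tested in a functional assay on DA-3 cells for cytotoxicity against DA-3 cell line (Mus musculus), read by MTT assay; a lower number here means a stronger inhibitor, a higher number a weaker inhibitor. Compound 1 (`CC(=O)O[C@@H]1OC(=O)[C@](Cc2ccccc2)(C(C)=O)[C@@H]1C`) gives 45000 nM in this assay, the highest of the two numbers available. Its nearest neighbour is compound 3 (`CC(=O)O[C@@H]1OC(=O)[C@@](Cc2ccccc2)(C(C)=O)[C@@H]1C`), which gives 44000 nM in this assay. The step of a 1.0-fold lower number from compound 1 to compound 3 (0.01 log units; within the scatter) is within the scatter, which fits with the fact that compounds 1 and 3 differ only in the configuration as drawn. Compound 2 (`CC(=O)O[C@@H]1OC(=O)[C@](C)(C(C)=O)[C@@H]1C(C)C`) carries a methyl in place of the benzyl and an isopropyl in place of the methyl of compound 1. In this assay compound 2 reaches only > 50000 nM, which is a limit of the assay and not a number, as seen from the limit of > 50000 nM in this assay, at which 1 of the 3 values shown sits.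

Compound 4 (`CC(=O)O[C@@H]1OC(=O)[C@@H](C(C)=O)[C@@H]1C`) has not yet been measured. It differs from compound 1 by hydrogen in place of benzyl on a saturated ring carbon. Among the compounds with values here, no measured step removes the benzyl, so none of the steps bears on this change directly; the only measured step, from compound 1 to compound 3, was within the scatter, and all three compounds cluster at weak values or at the limit. Compound 4 is therefore expected to give about 50000 nM in this assay, with a range from 20000 nM to 150000 nM, and a fair chance that only a limit is reported. The expected step of a 1.1-fold higher number from compound 1 to compound 4 (0.05 log units; within the scatter) is thus estimated to be small.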

Compound 4, half-maximal inhibitory concentration: > 50000 nM
Compound 4 was reported as a limit; the forecaster's own chance of this, stated with the estimate: 60%; the middle value lies on the limit itself.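

Removing the benzyl from this saturated ring carbon, two ring bonds from the ring oxygen, can now be read directly, and in this assay it gives an at least 1.1-fold higher number from compound 1 to compound 4 (0.04 log units; that floor lies within the scatter). As far as these compounds go, that step rests on a limit of the assay, not on a number, so it shows that losing the benzyl brings no stronger inhibition here, while the true size of any weakening stays unknown, and there may be none. Measurements this close to the top of the range can say little about this change: the limit of > 50000 nM in this assay, at which 2 of the 4 values shown sit.

The compounds shown leave open whether any other group on this carbon, such as an amine, a carboxylic acid or a longer chain, would bring the number clearly down from the values seen so far. Compound 2 differs from compound 1 in two places at once, so the effect of a methyl on this carbon cannot be separated from that of the isopropyl on the neighbouring part of the core.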